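A few compounds are considered here, and "the series" means these few. Any claim that something is new, unique, unknown or untested is made for them only; others in the source may bear on it.

Working notes on the series. Compound 3 `O=C1Nc2c(ccc(F)c2F)C1(c1ccc(O)cc1)c1ccc(F)c(F)c1` gives 19 nM in a functional assay on PC-3 cells (Homo sapiens) for cytotoxicity, read by WST assay, with a stated time of 72 h; a higher number here means a weaker inhibitor, a lower number a stronger inhibitor. Among the three numbers so far, compound 3 stands second highest: nearest is compound 1 `O=C1Nc2c(ccc(F)c2F)C1(c1ccccc1)c1ccc(O)cc1`, which in this assay gives 8.9 nM; furthest is compound 2 `COc1ccc(C2(c3cccc(O)c3)C(=O)Nc3c2ccc(F)c3F)cc1`, which in this assay gives 145 nM. Within the data shown here, the one measured step at the saturated ring carbon is a 2.1-fold higher number from compound 1 to compound 3 (0.33 log units; beyond the scatter). Compound 4 `O=C1Nc2c(ccc(F)c2F)C1(c1ccc(O)cc1)C1CCCC1` differs from compound 3 in that same place: cyclopentyl in place of 3,4-difluorophenyl on a saturated ring carbon. Among the measured compounds shown here, no measured step exchanges an aromatic ring for a non-aromatic one, so the expectation rests on the modest loss in a 2.1-fold higher number from compound 1 to compound 3 (0.33 log units; beyond the scatter) and on the wide spread down to compound 2. A somewhat higher number is expected for compound 4 in this assay, a step of a 2.6-fold higher number from compound 3 to compound 4 (0.42 log units; beyond the scatter), with an estimate of 50 nM and a range from 15 nM to 200 nM.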

Compound 4, half-maximal inhibitory concentration: 8.2 nM
For compound 4 the middle estimate is 6.1-fold (0.79 log units) above the measured one, and the stated range ends above it.
By their numbers in this assay, from the lowest: compounds 4 and 1 (each within the scatter of the next); then compound 3; then compound 2.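

At the saturated ring carbon in this assay, an aromatic ring is not needed for a low number: cyclopentyl in place of 3,4-difluorophenyl gives a lower number (a 2.3-fold lower number from compound 3 to compound 4 (0.36 log units; beyond the scatter)). Set against the unsubstituted phenyl, cyclopentyl shows no separation (a 1.1-fold lower number from compound 1 to compound 4 (0.04 log units; within the scatter)), so a non-aromatic ring of carbon only serves here as well as phenyl. No evidence at hand explains either step. Still open, on these data alone, is how a cyclopropyl ring, an open butyl chain or a piperidine ring carrying an amine would read at this carbon.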